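The source may hold more compounds than are shown below. What is called first, only, known or untested is meant among the compounds shown, and "the series" means these compounds.

Working notes on the series, cytotoxicity leg. Compound 1 `O=C(CSc1nnc(-c2ccncc2)o1)N/N=C/c1ccc(Br)cc1` gives 169000 nM in an ADME assay on NIH3T3 cells (Mus musculus) for cytotoxicity, read by MTT assay, with a stated time of 24 h; on this read-out higher numbers stand for weaker inhibition and lower numbers for stronger inhibition. Compound 2 `O=C(CSc1nnc(-c2ccncc2)o1)N/N=C/c1ccccc1F` gives 142000 nM in the same assay. Within the data shown here, the only measured step, a 1.2-fold lower number from compound 1 to compound 2 (0.08 log units; within the scatter), is a swap of the aryl group on the carbon with a double bond to nitrogen, and its size is within the scatter, so compound 2 and compound 1 cannot be told apart on these numbers; compound 2 simply sits alongside compound 1 at the weak end of what this assay reads.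

The next compound, compound 3 `O=C(CSc1nnc(-c2ccncc2)o1)N/N=C/c1cc(Br)cc(Br)c1O`, carries 3,5-dibromo-2-hydroxyphenyl in place of 2-fluorophenyl on a carbon with a double bond to nitrogen. Among the measured compounds shown here, the step that bears on it is a 1.2-fold lower number from compound 1 to compound 2 (0.08 log units; within the scatter), the one earlier change at the same position, which left the read-out unchanged beyond the scatter. On that single precedent a step of no more than the scatter is expected for a 1.1-fold lower number from compound 2 to compound 3 (0.04 log units; within the scatter); the data give no basis for a direction. Compound 3 is therefore estimated at 130000 nM, with a range from 50000 nM to 340000 nM.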

Compound 3, half-maximal inhibitory concentration: 190000 nM
Beside the measured number, compound 3's estimate is 1.5-fold (0.16 log units) below it; low and high end bracket the measured number.
By their numbers in this assay, from the lowest: compounds 2, 1 and 3 (each within the scatter of the next).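

At this position, the carbon with a double bond to nitrogen, the read-out in this assay holds even when 3,5-dibromo-2-hydroxyphenyl enters, bringing bromine, a hydrogen-bond donor and a hydrogen-bond acceptor that 2-fluorophenyl lacks: the result is a 1.3-fold higher number from compound 2 to compound 3 (0.13 log units; within the scatter), and against the 4-bromophenyl compound it is a 1.1-fold higher number from compound 1 to compound 3 (0.05 log units; within the scatter). Earlier, only the exchange of one halogen-bearing phenyl for another had been seen, whereas the flat result now extends to a group that also carries a hydroxyl, and compounds 1, 2 and 3 cannot be told apart, with none of the three going against this. No measurement at hand accounts for this lack of separation.

The compounds shown leave open whether a group of another kind at this position, such as a carboxylic acid or a dimethylamino group on the phenyl ring, or a saturated cyclohexyl ring in place of the phenyl, would move the number beyond the scatter. They also leave open whether a change in the shared core, rather than at this position, would do so.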